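The source may hold more compounds than are shown below. What is called first, only, known or untested is meant among the compounds shown, and "the series" means these compounds.

Measured so far in an ADME assay on HT-29 cells (Homo sapiens) for cytotoxicity, read by MTT assay, with a stated time of 72 h; a lower number here means a stronger inhibitor, a higher number a weaker inhibitor:
compound 1, `C=CC(=O)Nc1cc(Nc2ncc3ncn(-c4ccc(CC)cc4)c3n2)c(OC)cc1N(C)CCN(C)C`, gives 8180 nM
compound 2, `C=CC(=O)Nc1cc(Nc2ncc3ncn(-c4ccc(Br)cc4)c3n2)c(OC)cc1N(C)CCN(C)C`, gives 1460 nM

For the measured compounds named here, compound 2 stands at the lower of the two numbers; its only neighbour is compound 1, with a 5.6-fold lower number from compound 1 to compound 2 (0.75 log units; beyond the scatter) separating them. Compound 3, `C=CC(=O)Nc1cc(Nc2ncc3ncn(-c4ccc(I)cc4)c3n2)c(OC)cc1N(C)CCN(C)C`, differs from compound 2 by iodo in place of bromo on an aromatic carbon. Going by the values given here, the sole measured step bearing on this place is a 5.6-fold lower number from compound 1 to compound 2 (0.75 log units; beyond the scatter), which covers an exchange of ethyl for bromo and was modest in size. Among the compounds with values here, no measured step covers an exchange of one halogen for another, so the bromo-to-iodo change has no direct precedent; both compounds keep the same substitution at this place and the same shared core. The step is therefore expected to be small, a 1.2-fold lower number from compound 2 to compound 3 (0.09 log units; within the scatter), not beyond the scatter in either direction. Compound 3 is expected to give 1200 nM, with a range of 450 nM to 3200 nM.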

Compound 3, half-maximal inhibitory concentration: 9520 nM
Compound 3: middle estimate off by 7.9-fold (0.90 log units), on the low side; the whole stated range lies below it.
By their numbers in this assay, from the lowest: compound 2; then compounds 1 and 3 (each within the scatter of the next).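

In this assay, the change from 4-bromophenyl to 4-iodophenyl is not a neutral exchange of one halogen for another: a 6.5-fold higher number from compound 2 to compound 3 (0.81 log units; beyond the scatter) shows that replacing one heavy atom on this aromatic carbon, para to a large group, can shift the number beyond the scatter. With a 1.2-fold higher number from compound 1 to compound 3 (0.07 log units; within the scatter) lying within the scatter, iodo and ethyl cannot be told apart here, so the series does not divide into halogens and carbon groups, and among these three compounds the low number belongs to bromo alone. No supporting data are available to explain why bromo stands apart from iodo and ethyl.

From the compounds shown here alone, it remains open whether chloro or fluoro would fall with bromo or with iodo, and how a methoxy group or an amine would read at this place. The bromo result also rests on compound 2 alone, so whether it is a narrow optimum or an isolated value stays unsettled.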